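The compounds below may be only part of what the source reports. "The series", "measured", "known", "first", "only" and "open" are said of these compounds alone.

Measured so far:
compound 1 `CCC/C=C/C(=O)Nc1cc2c(N3CCc4ccccc43)ncnc2cc1OC` — 4240 nM
compound 2 `CCN(CC)C/C=C/C(=O)Nc1cc2c(N3CCc4ccccc43)ncnc2cc1OC` — 3690 nM

In a functional assay on PC-3 cells (Homo sapiens) for antiproliferative activity, read by MTT assay, with a stated time of 72 h (a lower number here means a stronger inhibitor, a higher number a weaker inhibitor), compound 2 stands together with compound 1 inside the usual scatter, the step being a 1.1-fold lower number from compound 1 to compound 2 (0.06 log units; within the scatter). Compound 3 `COc1cc2ncnc(N3CCc4ccccc43)c2cc1NC(=O)/C=C/CN1CCN(C)CC1` differs from compound 2 by 4-methylpiperazin-1-yl in place of diethylamino on a saturated chain carbon bound to a double-bonded chain carbon. Among the compounds with values here, the only step that bears on this change is a 1.1-fold lower number from compound 1 to compound 2 (0.06 log units; within the scatter), which swapped the group at the same place and left the number essentially unmoved. For compound 3 the expected step is therefore a 1.1-fold lower number from compound 2 to compound 3 (0.02 log units; within the scatter), nothing beyond the scatter. Compound 3 is expected to give about 3500 nM, within 1500 nM to 8500 nM.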

Compound 3, half-maximal inhibitory concentration: 9180 nM
Beside the measured number, compound 3's estimate is 2.6-fold (0.42 log units) below it; measured number above the stated range.
By their numbers in this assay, from the lowest: compounds 2 and 1 (each within the scatter of the next); then compound 3.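

In this assay, within the data shown here, the step of a 2.5-fold higher number from compound 2 to compound 3 (0.40 log units; beyond the scatter) is the first beyond the scatter, so this saturated chain carbon bound to a double-bonded chain carbon does respond to the group it carries. Against ethyl the direction is the same, with a 2.2-fold higher number from compound 1 to compound 3 (0.34 log units; beyond the scatter) for 4-methylpiperazin-1-yl in place of ethyl. No measurement at hand bears on the reason for this shift.

Open, going by these compounds, is whether the higher number goes with the six-membered ring or with its second nitrogen. Piperidin-1-yl or morpholin-4-yl at this place would bear on that.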